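From methoxycarbonyl to sulfamoylmethyl on the shared core

The source may hold more compounds than are shown below. What is called first, only, known or untested is meant among the compounds shown, and "the series" means these compounds.

Compound 1 `CCCn1c(=N)sc2cc(OC(F)(F)F)ccc21` with 4.5 mg/kg
Compound 2 `N#CCn1c(=N)sc2cc(OC(F)(F)F)ccc21` with 3.5 mg/kg
Compound 3 `COC(=O)Cn1c(=N)sc2cc(OC(F)(F)F)ccc21` with > 10 mg/kg (a limit)

In a functional assay on the whole organism with Rattus norvegicus as the target (a lower number here means that less compound is needed, a higher number that more compound is needed for the effect), compound 3 gives > 10 mg/kg as a limit of the assay and not as a number. Compound 4 `N=c1sc2cc(OC(F)(F)F)ccc2n1CCS(N)(=O)=O` differs from it by sulfamoylmethyl in place of methoxycarbonyl on a saturated chain carbon bound to an aromatic nitrogen in one place, with sulfamoylmethyl in place of methoxycarbonyl on a saturated chain carbon bound to an aromatic nitrogen. Bringing methoxycarbonyl in gave an at least 2.2-fold higher number from compound 1 to compound 3 (0.34 log units; beyond the scatter) and an at least 2.8-fold higher number from compound 2 to compound 3 (0.45 log units; beyond the scatter) among the measured compounds, so its departure is expected to give a modest move to a lower number, although no measured compound carries sulfamoylmethyl. Also measured is a 1.3-fold lower number from compound 1 to compound 2 (0.11 log units; within the scatter) and it adds no direction. The expected change is an at least 1.6-fold lower number from compound 3 to compound 4 (0.22 log units; that floor lies within the scatter) and is only roughly known. For compound 4 the estimate is 6 mg/kg with an expected range of 2.5 mg/kg to 15 mg/kg around it.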

Compound 4, dose for half-maximal effect: 6 mg/kg
Compound 4: middle estimate and measured number agree at the digits printed, within the range that was stated.
By their numbers in this assay, from the lowest: compounds 2, 1 and 4 (each within the scatter of the next). At a limit, above all of these: compound 3.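

In this assay, a sulfamoyl-bearing chain at this position falls in with the propyl and cyanomethyl compounds: the steps are a 1.3-fold higher number from compound 1 to compound 4 (0.12 log units; within the scatter) and a 1.7-fold higher number from compound 2 to compound 4 (0.23 log units; within the scatter), so these values do not separate. Set against the ester, the change gives an at least 1.6-fold lower number from compound 3 to compound 4 (0.22 log units; that floor lies within the scatter), which is a floor and not a measured size. Compound 3 stands at a limit of the assay and not at a number: the limit of > 10 mg/kg in this assay, at which 1 of the 4 values shown sits.

As far as these compounds go, it remains open whether the loss belongs to the methyl ester alone, which a carboxylic acid or a primary amide on the same chain carbon would address. A longer chain ending in sulfamoyl would show how far this position reaches.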